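Changing the Piperazine Substituent of a Weakly Cytotoxic Amide

A few compounds are considered here, and "the series" means these few. Any claim that something is new, unique, unknown or untested is made for them only; others in the source may bear on it.

Of the compounds shown here, three sharing one core have been tested in a functional assay on HT-29 cells (Homo sapiens) for cytotoxicity, read by MTT assay, with a stated time of 24 h, tested at 16 ug/mL; a higher number here means a stronger effect of the compound at the concentration tested, a lower number a weaker effect. Compound 1 `Cn1cnnc1SCC(=O)Nc1ccc(-c2nc(-c3ccccc3)c(-c3ccccc3)n2C)cc1` gives 59.1%, compound 2 `Cc1nnc(SCC(=O)Nc2ccc(-c3nc(-c4ccccc4)c(-c4ccccc4)n3C)cc2)s1` gives 83.3%, and compound 3 `CN(C)/C=C/N1CCN(CC(=O)Nc2ccc(-c3nc(-c4ccccc4)c(-c4ccccc4)n3C)cc2)CC1` gives 28.2%. Compound 3 stands lowest of the three: the step of a number 30.9 percentage points lower from compound 1 to compound 3 (beyond the scatter) and the step of a number 55.1 percentage points lower from compound 2 to compound 3 (beyond the scatter) both lie beyond the scatter, so the piperazine-bearing compound 3 is clearly the weakest of the set. The step of a number 24.2 percentage points higher from compound 1 to compound 2 (beyond the scatter) shows that swapping one sulfur-linked heterocycle for another moves the number modestly.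

Compound 4 `COc1ccc(CN2CCN(CC(=O)Nc3ccc(-c4nc(-c5ccccc5)c(-c5ccccc5)n4C)cc3)CC2)cc1` differs from compound 3 in one place: 4-methoxybenzyl in place of 2-(dimethylamino)ethenyl on an amine nitrogen in a ring. Among the compounds with values here, no measured step changes a group on the piperazine nitrogen itself; the two steps reaching compound 3 replace the whole sulfur-linked heterocycle with the piperazine, and both are large downward moves. Within the data shown here, they say only that compound 3 sits low, not how a different group on the ring nitrogen would act. Compound 3 gives 28.2%, a number that leaves more room above than below. Among the measured compounds shown here, with no direct precedent, the expected step is therefore a number 7.8 percentage points higher from compound 3 to compound 4 (within the scatter), small and uncertain, leaning slightly upward. For compound 4 in this assay the estimate is 36%, within a range from 15% to 62%.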

Compound 4, a percentage reported as activity, at one concentration (the size of the read-out at that concentration, not a potency): 21.8%
Estimate against measurement, compound 4: 14.2 percentage points above; measured number inside the range.
By their numbers in this assay, from the lowest: compounds 4 and 3 (each within the scatter of the next); then compound 1; then compound 2.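

Within the data shown here, replacing 2-(dimethylamino)ethenyl with 4-methoxybenzyl on the amine nitrogen in the ring gives a number 6.4 percentage points lower from compound 3 to compound 4 (within the scatter), the first step in this set that changes a group on that nitrogen while the piperazine stays in place, so the two compounds cannot be told apart in this assay. The swap is not a small one on paper: a group of 5 heavy atoms with no ring and one double bond gives way to a group of 9 heavy atoms with a six-membered aromatic ring of carbon only, yet this pair shows no clear change in the read-out, and the low number of compound 3 does not depend on its 2-(dimethylamino)ethenyl group alone. Nothing available here explains why these two groups give such similar numbers.

Still open, on these data alone, is whether a much smaller group on the same nitrogen, such as a methyl or an acetyl, or a bare hydrogen on that nitrogen, would move the number beyond the scatter. As far as these compounds go, it is equally open whether a chlorine or a hydroxyl in place of the methoxy on the benzyl group would matter.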